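Chloro for hydroxy in a series held at a limit

The source may report more compounds than this note shows. Statements on the series, on what has been measured and on what is new or still open speak of the compounds shown alone.

In an ADME assay on Raji cells (Homo sapiens) for cytotoxicity, read by luminescence, with a stated time of 72 h (a lower number here means that less compound is needed, a higher number that more compound is needed for the effect), compound 1 `CCOC(=O)c1c(-c2cccc(-c3ccccc3)c2)[nH]c2cc(OC)ccc2c1=O` gives > 21500 nM which is a limit of the assay and not a number. Compound 2 `CCOC(=O)c1c(-c2cccc(-c3ccccc3)c2)[nH]c2cc(O)ccc2c1=O` gives > 21500 nM which is likewise only a limit. Compound 1 and compound 2 share the limit of > 21500 nM in this assay, at which 2 of the 2 values shown sit, and nothing firmer, so compound 2 has no numerical standing in the series.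

Compound 3 `CCOC(=O)c1c(-c2cccc(-c3ccccc3)c2)[nH]c2cc(Cl)ccc2c1=O` carries chloro in place of hydroxy on an aromatic carbon. Going by the values given here, the one measured step that bears on this carbon is a step that the two limits leave unreadable from compound 1 to compound 2 and it offers no size to carry over. No step beyond the scatter is therefore expected in this assay and no direction can be assigned. The expected step is a number no higher from compound 2 to compound 3 (the limit leaves the size open) by this estimate. For compound 3 the estimated value is 21500 nM with an expected range from 7000 nM to 40000 nM and a report as a limit is the likeliest outcome.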

Compound 3, half-maximal effective concentration: > 21500 nM
Compound 3: no number, only a limit (the forecaster's own chance of this, stated with the estimate: 80%); the middle value lies on the limit itself.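

No step can be read from compound 1 or compound 2 to compound 3 in this assay, since all three compounds stop at a limit and give no number: the limit of > 21500 nM in this assay, at which 3 of the 3 values shown sit.

Open, as far as these compounds go, is whether hydroxy, methoxy or chloro on this aromatic carbon differ at all, and in which direction.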